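Chain homologation on two anilide cores

This account rests on a few compounds, and the source may have more. Where it says the series, first, only, none or still open, it means among the compounds named here.

Compound 1 `CC/C=C/C(=O)Nc1cc2c(N3CCc4ccccc43)ncnc2cc1OC` and compound 2 `CCC/C=C/C(=O)Nc1cc2c(N3CCc4ccccc43)ncnc2cc1OC` share a core; compound 3 `C/C=C/C(=O)Nc1cc2c(N3CCCc4ccccc43)ncnc2cc1OC` carries a core built from the same atoms joined differently, and the difference between the two cores is not broken down here. In a functional assay on PC-3 cells (Homo sapiens) for antiproliferative activity, read by MTT assay, with a stated time of 72 h (on this read-out lower numbers stand for stronger inhibition and higher numbers for weaker inhibition), compound 1 gives 5890 nM, compound 2 gives 4240 nM and compound 3 gives 7520 nM. The change methyl in place of hydrogen on a saturated chain carbon, two bonds along the chain from a double-bonded chain carbon made a 1.4-fold lower number from compound 1 to compound 2 (0.14 log units; within the scatter). Compound 4 `CC/C=C/C(=O)Nc1cc2c(N3CCCc4ccccc43)ncnc2cc1OC` is compound 3 with methyl in place of hydrogen on a saturated chain carbon bound to a double-bonded chain carbon; this is the same kind of change, but the place differs, being bound to a double-bonded chain carbon rather than two bonds along the chain from one. The expected step is a 1.3-fold lower number from compound 3 to compound 4 (0.13 log units; within the scatter) in this assay, resting on a 1.4-fold lower number from compound 1 to compound 2 (0.14 log units; within the scatter) and therefore held within the scatter. For compound 4 the estimate in this assay is 5600 nM, within 2500 nM to 12000 nM.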

Compound 4, half-maximal inhibitory concentration: 6310 nM
Estimate against measurement, compound 4: 1.1-fold (0.05 log units) below, within the range that was stated.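

In this assay, adding the methyl on the core of compound 3 gives a 1.2-fold lower number from compound 3 to compound 4 (0.08 log units; within the scatter). Set beside the step on the other core, the change carries across with no difference that can be read: the same change on two cores in this assay, a 1.4-fold lower number (0.14 log units; within the scatter) from compound 1 to compound 2 and a 1.2-fold lower number (0.08 log units; within the scatter) from compound 3 to compound 4, 1.2-fold (0.07 log units) apart, within the scatter of two such steps. Among these compounds, both steps lie within the scatter, so the pair shows only that this change leaves the number about where it was on both cores; it does not show a real gain on either core, and it cannot separate the core from the place on the chain, which also differs between the two steps.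

The compounds shown leave open whether a chain longer than that of compound 2, or an amine on the chain, would move the number beyond the scatter on either core.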